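Para substitution on the aryl ring: from compound 2 to compound 3

A few compounds are considered here, and "the series" means these few. Any claim that something is new, unique, unknown or untested is made for them only; others in the source may bear on it.

Measured so far:
compound 1 `C#Cn1ccnc1C#Cc1ccc(C(C)(C)C)cc1` gives 2500 nM
compound 2 `C#Cn1ccnc1C#Cc1ccccc1` gives 6000 nM

Among the measured compounds shown here, compound 2 has the highest number of the two in a functional assay on A549 cells (Homo sapiens) for cytotoxicity, read by resazurin assay, with a stated time of 72 h; a lower number here means a stronger inhibitor, a higher number a weaker inhibitor; its nearest neighbour is compound 1, with a 2.4-fold higher number from compound 1 to compound 2 (0.38 log units; beyond the scatter) marking the single step between them, hydrogen in place of tert-butyl on an aromatic carbon.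

Compound 3 `C#Cn1ccnc1C#Cc1ccc(C(C)=O)cc1` has not been measured. It differs from compound 2 by acetyl in place of hydrogen on an aromatic carbon, the acetyl standing on the same aromatic carbon that carries the tert-butyl in compound 1.

For the measured compounds named here, only one step bears on this change, a 2.4-fold higher number from compound 1 to compound 2 (0.38 log units; beyond the scatter), which shows that putting a group of this kind onto that carbon lowered the number by a modest margin. Acetyl is not tert-butyl, and no other substituent at this position has been measured, so the direction cannot be taken from the data with confidence. The working expectation is a step of about a 1.2-fold lower number from compound 2 to compound 3 (0.08 log units; within the scatter), that is a number near that of compound 2 or somewhat lower, within the scatter or just beyond it.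

Compound 3 is therefore estimated at 5000 nM in this assay, with a range from 1500 nM to 15000 nM.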

Compound 3, half-maximal inhibitory concentration: 500 nM
Estimate against measurement, compound 3: 10-fold (1.00 log units) above, and the stated range ends above it.
By their numbers in this assay, from the lowest: compound 3; then compound 1; then compound 2.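

In this assay, this aromatic carbon proves far more responsive than the tert-butyl step alone could show, with acetyl in place of hydrogen giving a 12-fold lower number from compound 2 to compound 3 (1.08 log units; beyond the scatter) and so a large step where tert-butyl gave a modest one. The outcome depends on which group stands there and not only on the carbon being substituted, as the comparison of the two groups on the same carbon gives a 5.0-fold lower number from compound 1 to compound 3 (0.70 log units; beyond the scatter) in favour of acetyl, which leaves compound 3 with the lowest number of the three, its steps to both others lying beyond the scatter. Nothing available explains why acetyl does so much better than tert-butyl or hydrogen.

From the compounds shown here alone, whether the gain belongs to acetyl alone or extends to other groups on this carbon, such as a carboxylic acid, an amine, a nitrile or a longer acyl chain, remains open. Also open, going by these compounds, is whether acetyl on another carbon of the six-membered aromatic ring would give a step of similar size in this assay or whether the effect is tied to this one place.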